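Adding a Carboxy Group to the Benzyl Ring of Compound 2

This account rests on a few compounds, and the source may have more. Where it says the series, first, only, none or still open, it means among the compounds named here.

Of the compounds shown here, three sharing one core have been measured in a functional assay on SK-OV-3 cells (Homo sapiens) for inhibition, read by CCK-8 assay, with a stated time of 70 h; on this read-out higher numbers stand for weaker inhibition and lower numbers for stronger inhibition. Compound 1 `c1ccc(COc2ccc(OCCOCCNc3ccccc3)cc2)cc1` reaches only the limit of > 100000 nM in this assay, a limit and not a number. Compound 2 `c1ccc(COc2ccc(OCCOCCNC3CCCC3)cc2)cc1` gives 24800 nM in this assay. Compound 3 `OCCOCCOCCOc1ccc(OCc2ccccc2)cc1` gives 59400 nM in this assay. Compound 2 therefore has the lowest number of the two that were measured, with compound 3 next, and compound 1 sitting at a limit. The steps between them are an at least 4.0-fold lower number from compound 1 to compound 2 (0.60 log units; beyond the scatter), an at least 1.6-fold lower number from compound 1 to compound 3 (0.22 log units; that floor lies within the scatter) and a 2.4-fold higher number from compound 2 to compound 3 (0.38 log units; beyond the scatter), all at the amine end of the chain.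

Compound 4 `O=C(O)c1cccc(COc2ccc(OCCOCCNC3CCCC3)cc2)c1` differs from compound 2 only at the other end: carboxy in place of hydrogen on an aromatic carbon. Within the data shown here, none of the measured steps changes that ring, so nothing measured here speaks to this change, and the benzyl ring otherwise stays as it is in compound 2. Among the measured compounds shown here, with no step to lean on, the expectation is one of no change beyond the scatter, with a wide margin for surprise. Compound 4 is therefore expected to give 25000 nM in this assay, somewhere between 7000 nM and 90000 nM, which means an expected step of a 1.0-fold higher number from compound 2 to compound 4 (0.00 log units; within the scatter).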

Compound 4, half-maximal inhibitory concentration: > 100000 nM
Compound 4: no number, only a limit; the forecaster's own chance of this, stated with the estimate: 15%; at least 4.0-fold (0.60 log units) between middle value and limit.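

The earlier compounds shown here changed only the amine end of the chain, so they said nothing about the benzyl ring; this result shows that the ring is not a part that can be altered freely. In this assay, putting a carboxy group on it gives an at least 4.0-fold higher number from compound 2 to compound 4 (0.60 log units; beyond the scatter), so the change weakens inhibition by more than the usual scatter, even though it lies at the opposite end of the molecule from the earlier changes. Compound 4 reaches only a limit and not a number, so this step marks a minimum and its full size cannot be read: the limit of > 100000 nM in this assay, at which 2 of the 4 values shown sit.

The compounds shown leave open whether this result belongs to the carboxylic acid itself, or whether its methyl ester or primary amide at the same place would give the same outcome. Also open, on these data alone, is whether a small group such as fluorine or methoxy on this ring would be tolerated, and whether the carboxy group would act in the same way with a different group at the amine end of the chain.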